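Halogen swap on a thiosemicarbazone core: cytotoxicity stays at limit

A few compounds are considered here, and "the series" means these few. Any claim that something is new, unique, unknown or untested is made for them only; others in the source may bear on it.

Compound 1, `O=C1Nc2ccccc2/C1=N/NC(=S)Nc1ccc(Cl)cc1`, in an ADME assay on RD cells (Homo sapiens) for cytotoxicity (a lower number here means that less compound is tolerated, a higher number that more compound is tolerated), gives > 25000 nM, which is a limit of the assay and not a number.
Compound 2, `O=C1Nc2ccccc2/C1=N/NC(=S)Nc1ccc(Br)cc1`, gives > 25000 nM, again a limit rather than a number.
Compound 3, `O=C1Nc2ccc(Cl)cc2/C1=N/NC(=S)Nc1ccccc1`, gives > 25000 nM, also a limit.

All three measured values sit at the limit of > 25000 nM in this assay, at which 3 of the 3 values shown sit. Compound 1 and compound 2 differ by bromo in place of chloro on an aromatic carbon, and the step that the two limits leave unreadable from compound 1 to compound 2. Compound 3 has the same atoms as compound 1 joined differently; the difference between the two cores is not broken down here.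

The compound still to be measured, compound 4, `O=C1Nc2ccc(Br)cc2/C1=N/NC(=S)Nc1ccccc1`, is made from compound 3 by bromo in place of chloro on an aromatic carbon. Among the compounds with values here, this is the same kind of change as the one from compound 1 to compound 2, but it sits in a different place: in compound 2 the bromo stands on a six-membered aromatic ring of carbon only, para to a large group, whereas in compound 4 it stands on such a ring that is part of a fused or bridged system of two rings, meta to a fused ring and para to a fused ring. Because every measured value sits at the limit of > 25000 nM in this assay, at which 3 of the 3 values shown sit, the step is expected to read as a step that the limit leaves unreadable from compound 3 to compound 4, that is, to remain hidden behind the same limit. In this assay compound 4 is expected to give about 50000 nM, most likely reported only as a limit again, within a plausible range from 25000 nM to 200000 nM.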

Compound 4, half-maximal cytotoxic concentration: > 25000 nM
Compound 4: a limit, no number (the forecaster's own chance of this, stated with the estimate: 90%); the middle value does not contradict the limit.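

The swap of chloro for bromo between compound 3 and compound 4 gives no readable step, since both values are limits and not numbers: the limit of > 25000 nM in this assay, at which 4 of the 4 values shown sit.

The compounds shown leave open how far their cytotoxicity in this assay really differs, and whether any change to the shared core would give a value that is an actual number.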